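Aryl exchange on the chain carbon: compound 3 to compound 4

This account rests on a few compounds, and the source may have more. Where it says the series, first, only, none or still open, it means among the compounds named here.

Measured so far in a functional assay on M14 cells (Homo sapiens) for cytotoxicity, read by MTT assay, with a stated time of 72 h; on this read-out lower numbers stand for stronger inhibition and higher numbers for weaker inhibition:
compound 1 `CC(=O)n1cc(/C=C(/C(=O)O)c2ccccc2)c2cc(OCc3ccccc3)ccc21` gives > 100000 nM, a limit of the assay.
compound 2 `COc1cc(/C(=C\c2cn(C(C)=O)c3ccc(OCc4ccccc4)cc23)C(=O)O)cc(OC)c1OC` gives 57100 nM.
compound 3 `CC(=O)n1cc(/C=C(/C(=O)O)c2ccc(Cl)cc2)c2cc(OCc3ccccc3)ccc21` gives > 100000 nM, a limit of the assay.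

Compound 3 stands at the limit of > 100000 nM in this assay, at which 2 of the 3 values shown sit, with only a limit known. The step to compound 4 `COc1ccc(/C(=C\c2cn(C(C)=O)c3ccc(OCc4ccccc4)cc23)C(=O)O)cc1OC` is 3,4-dimethoxyphenyl in place of 4-chlorophenyl on a double-bonded chain carbon bound to a carbonyl carbon and a double-bonded chain carbon. For the measured compounds named here, two measured steps bear on it: an at least 1.7-fold higher number from compound 2 to compound 3 (0.24 log units; that floor lies within the scatter) and an at least 1.7-fold lower number from compound 1 to compound 2 (0.24 log units; that floor lies within the scatter), both floors that lie within the scatter. A dimethoxy pattern sits between the phenyl of compound 1 and the trimethoxyphenyl of compound 2, so no step beyond the scatter is expected in this assay. Compound 4 is expected near 80000 nM, in the range 40000 nM to 200000 nM. That estimate means an expected step of an at least 1.2-fold lower number from compound 3 to compound 4 (0.09 log units; that floor lies within the scatter).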

Compound 4, half-maximal inhibitory concentration: 65500 nM
The estimate for compound 4 lay 1.2-fold (0.09 log units) above the measured number; the range from low to high includes it.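

In this assay, hydrogen in place of methoxy on an aromatic carbon gives a 1.1-fold higher number from compound 2 to compound 4 (0.06 log units; within the scatter) and so leaves compound 4 and compound 2 level within the scatter, with both methoxy-bearing aryl groups on the double-bonded chain carbon reading as numbers. The floors (in an at least 1.5-fold lower number from compound 3 to compound 4 (0.18 log units; that floor lies within the scatter) and in an at least 1.5-fold lower number from compound 1 to compound 4 (0.18 log units; that floor lies within the scatter)) lie within the scatter too, so 3,4-dimethoxyphenyl is not set apart from 4-chlorophenyl or phenyl. Compound 1 and compound 3 stay limits, not numbers: the limit of > 100000 nM in this assay, at which 2 of the 4 values shown sit.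

Open, from the compounds shown here alone, is whether a single methoxy on the phenyl behaves like the 3,4-dimethoxyphenyl group. Also open, going by these compounds, is what an amine or a longer chain on this carbon would give in this assay on the shared core.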